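The source may hold more compounds than are shown below. What is called first, only, known or untested is meant among the compounds shown, and "the series" means these compounds.

Compound 3 `C[C@H](NC(=O)C(c1cccnc1)N(C(=O)c1ccco1)c1ccc(-c2ccccc2)cc1)c1ccccc1` is the one for which only a limit is known: in a toxicity assay on Vero C1008 cells (Chlorocebus sabaeus) for cytotoxicity, read by neutral red uptake, with a stated time of 5 days (a lower number here means that less compound is tolerated, a higher number that more compound is tolerated), compound 3 gives > 200000 nM, which is a limit of the assay rather than a number (the limit of > 200000 nM in this assay, at which 1 of the 3 values shown sits). Compound 1 `C[C@H](NC(=O)C(c1cccnc1)N(C(=O)c1ccco1)c1ccc([Si](C)(C)C)cc1)c1ccccc1` and compound 2 `C[C@H](NC(=O)C(c1cccnc1)N(C(=O)c1ccco1)c1ccc(C2CCCCC2)cc1)c1ccccc1` carry different groups on the same aromatic carbon; in this assay compound 1 gives 19400 nM and compound 2 gives 9610 nM. The steps of an at least 10-fold higher number from compound 1 to compound 3 (1.01 log units; beyond the scatter) and an at least 20-fold higher number from compound 2 to compound 3 (1.31 log units; beyond the scatter) concern that aromatic carbon alone. Compound 4 `O=C(NC1CCCCC1)C(c1cccnc1)N(C(=O)c1ccco1)c1ccc(-c2ccccc2)cc1` differs from compound 3 elsewhere: cyclohexyl in place of 1-phenylethyl on an amide-type nitrogen. Within the data shown here, no measured step touches the amide-type nitrogen, so the expected step is a number no higher from compound 3 to compound 4 (the limit leaves the size open), nothing beyond the scatter. Compound 4 is therefore estimated at 200000 nM, between 60000 nM and 400000 nM.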

Compound 4, half-maximal cytotoxic concentration: 53500 nM
Compound 4: the middle estimate sits 3.7-fold (0.57 log units) above what was measured, outside the stated range (below it).
By their numbers in this assay, from the lowest: compound 2; then compound 1; then compound 4. At a limit, above all of these: compound 3.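

In this assay, the amide-type nitrogen also proves to matter, not only the aromatic carbon: cyclohexyl in place of 1-phenylethyl gives an at least 3.7-fold lower number from compound 3 to compound 4 (0.57 log units; beyond the scatter). As far as these compounds go, the full size of this step stays open, since the value of compound 3 is a limit of the assay and not a number: the limit of > 200000 nM in this assay, at which 1 of the 4 values shown sits. At both places, cyclohexyl goes with the lower number, in compound 2 against compound 3 and in compound 4 against compound 3.

From the compounds shown here alone, how a benzyl group or a chain bearing an amine on this nitrogen would read remains open. So does whether cyclohexyl here has the same effect with the aromatic-carbon groups of compound 1 or compound 2.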